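Sulfonyl substituent series: phenoxy in place of the sulfonamide

This account rests on a few compounds, and the source may have more. Where it says the series, first, only, none or still open, it means among the compounds named here.

Of the compounds shown here, two have been measured in a functional assay on the whole organism (aorta) with Rattus norvegicus as the target; a higher number here means a larger maximal response, a lower number a smaller maximal response. Compound 1 `CC(C)NS(=O)(=O)c1ccc2c(c1)C(n1ccccc1=O)=CC(C)(C)O2` gives 76.9% in this assay. Compound 2 `CN(c1ccccc1)S(=O)(=O)c1ccc2c(c1)C(n1ccccc1=O)=CC(C)(C)O2` gives 64.2% in this assay and stands lowest of the two numbers; its nearest neighbour is compound 1, which lies above it beyond the scatter. Within the data shown here, the single measured step, a number 12.7 percentage points lower from compound 1 to compound 2 (beyond the scatter), concerns a substituent on the same sulfonyl sulfur.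

Compound 3 `CC1(C)C=C(n2ccccc2=O)c2cc(S(=O)(=O)Oc3ccccc3)ccc2O1` has not been measured. It differs from compound 2 in one place: phenoxy in place of methyl(phenyl)amino on a sulfonyl sulfur. The measured step bears on this change only in that it alters the same sulfonyl sulfur, and there a number 12.7 percentage points lower from compound 1 to compound 2 (beyond the scatter) was modest. Among the measured compounds shown here, no measured pair shows what replacing methyl(phenyl)amino by phenoxy does, so the direction is open. The expected step is therefore small, a number 2.2 percentage points lower from compound 2 to compound 3 (within the scatter), and may well fall within the scatter. Compound 3 is estimated to give 62% in this assay, with a range from 42% to 82% reflecting the missing comparison.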

Compound 3, largest response reached (Emax), in percent of the reference or control that the assay uses: 67.9%
Estimate against measurement, compound 3: 5.9 percentage points below; measured number inside the range.
By their numbers in this assay, from the lowest: compounds 2, 3 and 1 (each within the scatter of the next, the first and the last beyond it).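

At this sulfonyl sulfur, phenoxy in place of methyl(phenyl)amino makes no readable difference in this assay (a number 3.7 percentage points higher from compound 2 to compound 3 (within the scatter)), so a sulfonate-type phenoxy and a tertiary sulfonamide bearing phenyl are not told apart by this read-out. Phenoxy in place of isopropylamino also stays inside the scatter (a number 9 percentage points lower from compound 1 to compound 3 (within the scatter)), which places compound 3 within reach of both sulfonamides, even though compound 1 and compound 2 are themselves separated (a number 12.7 percentage points lower from compound 1 to compound 2 (beyond the scatter)); the three compounds therefore give no clean ranking by the group on the sulfur, only a single gap between its two ends. No accompanying data bear on why these numbers fall as they do.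

As far as these compounds go, what remains open is whether isopropoxy on the sulfonyl sulfur would track isopropylamino the way phenoxy tracks methyl(phenyl)amino, a pairing that would test the exchange away from an aromatic substituent. Also open, from the compounds shown here alone, is how far the maximal response moves with a group of another kind at this sulfur, such as a plain amino group, a morpholine or a simple methyl.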